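A few compounds are considered here, and "the series" means these few. Any claim that something is new, unique, unknown or untested is made for them only; others in the source may bear on it.

Compound 2 `Cn1cc(-c2c(-c3ccc(S(C)(=O)=O)cc3)oc3ccccc3c2=O)cn1` is one of three measured members of a set of compounds sharing one core. In an assay on isolated protein for inhibition of prostaglandin G/H synthase 1 (Mus musculus), tested at 10 ug/mL (on this read-out higher numbers stand for more inhibition at the one concentration tested (going by the name of the read-out) and lower numbers for less inhibition), compound 2 reaches only the limit < 5%, a limit of the assay and not a number, so its own standing on the scale is known only as the limit of < 5% in this assay, at which 1 of the 3 values shown sits. The two companions carry a para-substituted phenyl at the same place: compound 1 `NS(=O)(=O)c1ccc(-c2oc3ccccc3c(=O)c2-c2ccc(F)cc2)cc1` gives 67% in this assay, and compound 3 `CSc1ccc(-c2c(-c3ccc(S(N)(=O)=O)cc3)oc3ccccc3c2=O)cc1` gives 90%. For the measured compounds named here, the one measured step, a number 23 percentage points higher from compound 1 to compound 3 (beyond the scatter), concerns a different position and does not bear directly on the change to compound 4 `Cc1ccccc1-c1c(-c2ccc(S(C)(=O)=O)cc2)oc2ccccc2c1=O`, which is 2-methylphenyl in place of 1-methyl-1H-pyrazol-4-yl on an aromatic carbon. Going by the values given here, no measured step covers this exchange, and compounds 1 and 3 also differ from compound 4 in the sulfonyl group. Since both aryl-bearing compounds 1 and 3 show clear inhibition while compound 2 sits at the limit, compound 4 is expected to rise to a measurable value, giving an expected step of a number at least 40 percentage points higher from compound 2 to compound 4 (beyond the scatter). For compound 4 the estimate is 45%, within a range from 10% to 80%.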

Compound 4, a percentage reported as inhibition, at one concentration (the size of the read-out at that concentration, not a potency): < 5%
Compound 4: a limit, no number; the forecaster's own chance of this, stated with the estimate: 20%; middle value at least 40 percentage points away from the limit.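

In this assay, for the compounds shown here, compound 4 gives < 5%, a limit of the assay and not a number, as compound 2 also does, so no step between compound 2 and compound 4 can be read. The compounds shown leave open what the sulfonyl group separating these two from compound 1 and compound 3 contributes: no pair shown differs only there.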